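The compounds below may be only part of what the source reports. "The series", "measured", "known", "first", "only" and "open" are said of these compounds alone.

Measured so far in an ADME assay on microsomes from liver (Homo sapiens) for metabolic stability, with a stated time of 10 min; a lower number here means that less of the compound is left, a higher number that more of the compound is left:
Compound 1 `CC(C)(C)NC(=O)NCCS(=O)(=O)NC(=O)c1ccc(Nc2nc(NC3(c4ccc(Cl)cc4)CC3)nc(OCC(F)(F)F)n2)cc1` gives 96%.
Compound 2 `CC(C)OC(=O)NCCS(=O)(=O)NC(=O)c1ccc(Nc2nc(NC3(c4ccc(Cl)cc4)CC3)nc(OCC(F)(F)F)n2)cc1` gives 100%.
Compound 3 `CC(C)(C)CNCCS(=O)(=O)NC(=O)c1ccc(Nc2nc(NC3(c4ccc(Cl)cc4)CC3)nc(OCC(F)(F)F)n2)cc1` gives 89%.

Compound 1 stands second highest of the three numbers; the nearest is compound 2, with a number 4 percentage points higher from compound 1 to compound 2 (within the scatter), and the furthest is compound 3, with a number 7 percentage points lower from compound 1 to compound 3 (within the scatter). Compound 4 `CC(C)NC(=O)NCCS(=O)(=O)NC(=O)c1ccc(Nc2nc(NC3(c4ccc(Cl)cc4)CC3)nc(OCC(F)(F)F)n2)cc1` differs from compound 1 by hydrogen in place of methyl on a saturated chain carbon bound to an amide-type nitrogen and two saturated chain carbons; cut one bond further out, this reads tert-butyl to isopropyl, (tert-butyl)carbamoyl to isopropylcarbamoyl. Going by the values given here, no measured step alters this group in the same way, so the bearing steps are those at the same chain end: a number 4 percentage points higher from compound 1 to compound 2 (within the scatter) and a number 7 percentage points lower from compound 1 to compound 3 (within the scatter) stay within the scatter although they exchange whole groups, and only a number 11 percentage points lower from compound 2 to compound 3 (beyond the scatter) goes modestly beyond it. The change to compound 4 is smaller than any of these exchanges, so in this assay no step beyond the scatter is expected, in either direction. For compound 4 the estimate is 93%, with a range of 80% to 100%, which means an expected a number 3 percentage points lower from compound 1 to compound 4 (within the scatter).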

Compound 4, percent of the compound remaining: 100%
Compound 4: the middle estimate sits 7 percentage points below what was measured; low and high end bracket the measured number.
By their numbers in this assay, from the lowest: compounds 3, 1, 2 and 4 (each within the scatter of the next, the first and the last beyond it).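

In this assay, tert-butyl to isopropyl on the carbamoyl group gives a number 4 percentage points higher from compound 1 to compound 4 (within the scatter), and isopropylamino in place of isopropoxy on the carbonyl carbon gives no change at the digits printed from compound 2 to compound 4 (within the scatter), so neither exchange at this chain end moves the read-out beyond the scatter. Isopropylcarbamoyl in place of neopentyl on the amine nitrogen gives a number 11 percentage points higher from compound 3 to compound 4 (beyond the scatter), a second modest step at this nitrogen alongside a number 11 percentage points lower from compound 2 to compound 3 (beyond the scatter), while a number 7 percentage points lower from compound 1 to compound 3 (within the scatter) goes against any general separation of the carbonyl-bearing groups from neopentyl. Nothing shown accounts for these steps.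

Compound 4 gives 100%, which leaves little room to tell further changes upward at this chain end. Open, going by these compounds, is how a cyclopropyl group, a longer chain, a primary amine or a carboxylic acid at this chain end would read in this assay.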